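The source may report more compounds than this note shows. Statements on the series, on what has been measured and on what is new or still open speak of the compounds shown alone.

Measured compounds:
Compound 1 `CC(C)[C@@H](NC(=O)c1nc2ccccc2s1)C(=O)N1CCC(c2ccc(Cl)cc2)CC1`: in an assay on THP-1 cells for displacement of a labelled ligand from C-C chemokine receptor type 1 (Homo sapiens) (a lower number here means a stronger inhibitor, a higher number a weaker inhibitor), compound 1 gives 18 nM.
Compound 2 `CC(C)[C@@H](NC(=O)CCCc1ccccc1)C(=O)N1CCC(c2ccc(Cl)cc2)CC1`: in this assay compound 2 gives 95 nM.

Compound 2 holds the higher of the two numbers, and the step of a 5.3-fold higher number from compound 1 to compound 2 (0.72 log units; beyond the scatter) shows that the group on the carbonyl carbon matters. Compound 3 `CC(C)[C@@H](NC(=O)C1CCCC1)C(=O)N1CCC(c2ccc(Cl)cc2)CC1` differs from compound 2 by cyclopentyl in place of 3-phenylpropyl on a carbonyl carbon. Among the measured compounds shown here, no measured step exchanges one group of this kind for another at that carbonyl carbon, so a 5.3-fold higher number from compound 1 to compound 2 (0.72 log units; beyond the scatter) is the only guide, and it suggests a change of modest size is possible in either direction. For compound 3 the expected step is a 1.6-fold higher number from compound 2 to compound 3 (0.20 log units; within the scatter). The estimate for compound 3 is 150 nM, with a range from 50 nM to 500 nM.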

Compound 3, half-maximal inhibitory concentration: 70 nM
Compound 3: middle estimate off by 2.1-fold (0.33 log units), on the high side, and the stated range covers the measured number.
By their numbers in this assay, from the lowest: compound 1; then compounds 3 and 2 (each within the scatter of the next).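

In this assay, cyclopentyl in place of 3-phenylpropyl on the carbonyl carbon gives a 1.4-fold lower number from compound 2 to compound 3 (0.13 log units; within the scatter), so these two groups cannot be told apart here, although one carries a six-membered aromatic ring and the other a five-membered non-aromatic ring. The 1,3-benzothiazol-2-yl group still stands apart, with a 3.9-fold higher number from compound 1 to compound 3 (0.59 log units; beyond the scatter). No measurement offers an explanation for this gap. Still open, from the compounds shown here alone, is how a pyridine ring, a plain phenyl ring or a carboxylic acid on this carbonyl carbon would compare with 1,3-benzothiazol-2-yl.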